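A Fluorobenzyl Replaces Cyclohexyl on a Shared Core

This account rests on a few compounds, and the source may have more. Where it says the series, first, only, none or still open, it means among the compounds named here.

compound 1, `CCCCc1cnc(Cc2ccc(-c3ccccc3C(=O)O)cc2)[nH]1`: > 10000 nM
compound 2, `O=C(O)c1ccccc1-c1ccc(CCc2ncc(C3CCCCC3)[nH]2)cc1`: 375 nM

Of the compounds shown here, two have been measured in an in vitro functional assay on cells for agonist activity at Bombesin receptor subtype-3 (Homo sapiens), read by luminescence and calcium flux; on this read-out lower numbers stand for an effect already at smaller amounts and higher numbers for an effect only at larger amounts of compound. For compound 1 the value > 10000 nM is a limit of this assay and not a number. Among the compounds with values here, compound 2 gives 375 nM in this assay, the only number among the values shown. Compound 3, `O=C(O)c1ccccc1-c1ccc(CCc2ncc(Cc3ccccc3F)[nH]2)cc1`, remains to be measured. It differs from compound 2 by 2-fluorobenzyl in place of cyclohexyl on an aromatic carbon. Within the data shown here, no pair of measured compounds differs in a single place, so no measured step sets a scale for this change. The exchange of one ring for another is expected to give, at most, a modest step in this assay, possibly none beyond the scatter, in either direction. Compound 3 is therefore estimated at 600 nM, with a range from 150 nM to 3000 nM. This corresponds to an expected step of a 1.6-fold higher number from compound 2 to compound 3 (0.20 log units; within the scatter).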

Compound 3, half-maximal effective concentration: 177 nM
Estimate against measurement, compound 3: 3.4-fold (0.53 log units) above; the range from low to high includes it.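

On the aromatic carbon of the five-membered aromatic ring with 2 nitrogen, the exchange of cyclohexyl for 2-fluorobenzyl gives a 2.1-fold lower number from compound 2 to compound 3 (0.33 log units; beyond the scatter) in this assay. This is the first measured step among these compounds, and it shows that this position takes an aromatic ring in the enterng group as well as the non-aromatic ring of cyclohexyl, with no loss on this read-out. Compound 1 differs from the others in more than one place and gives a limit of the assay and not a number, so it sets no scale for this change: the limit of > 10000 nM in this assay, at which 1 of the 3 values shown sits.

The compounds shown leave open whether the step belongs to the fluorine or to the benzyl itself. They also leave open how a plain benzyl, a 2-methoxybenzyl or a chain ending in an amine would read at this position in this assay.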